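Phenyl for Butyl: Expected Cytotoxicity of Compound 3

The source may hold more compounds than are shown below. What is called first, only, known or untested is meant among the compounds shown, and "the series" means these compounds.

Compound 1, `CCN1CCN(C(=S)SCC(O)Cn2cc([N+](=O)[O-])nc2C)CC1`: > 5000000 nM
Compound 2, `CCCCN1CCN(C(=S)SCC(O)Cn2cc([N+](=O)[O-])nc2C)CC1`: 4330000 nM

In a toxicity assay on HeLa cells (Homo sapiens) for cytotoxicity, read by MTT assay, with a stated time of 24 h (a higher number here means a weaker inhibitor, a lower number a stronger inhibitor), compound 1 gives a limit, > 5000000 nM, which is the limit of > 5000000 nM in this assay, at which 1 of the 2 values shown sits. Within the data shown here, compound 2 gives 4330000 nM, the only outright number so far. The step of an at least 1.1-fold lower number from compound 1 to compound 2 (0.06 log units; that floor lies within the scatter) lies within the scatter. Compound 3, `Cc1nc([N+](=O)[O-])cn1CC(O)CSC(=S)N1CCN(c2ccccc2)CC1`, differs from compound 2 by phenyl in place of butyl on an amine nitrogen in a ring. Among the measured compounds shown here, the measured step concerns a different group, so no measured step bears directly on this change, and nothing points to a shift beyond the scatter. For compound 3 the expected value is 3000000 nM, between 1000000 nM and 8000000 nM, an expected step of a 1.4-fold lower number from compound 2 to compound 3 (0.16 log units; within the scatter).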

Compound 3, half-maximal inhibitory concentration: > 5000000 nM
Compound 3 ended at the assay's limit; the forecaster's own chance of this, stated with the estimate: 30%; middle value at least 1.6-fold (0.22 log units) away from the limit.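

Compound 3 is the first shown with a ring rather than a chain on this amine nitrogen, and in this assay that change gives an at least 1.1-fold higher number from compound 2 to compound 3 (0.06 log units; that floor lies within the scatter). The step involving compound 1 and compound 3 cannot be read, as both values are limits. Compound 3 gives a limit, so the true size of its step from butyl stays hidden, and the limit now holds most of the series: the limit of > 5000000 nM in this assay, at which 2 of the 3 values shown sit.

Open, as far as these compounds go, is what a benzyl group or a chain ending in a carboxylic acid would give on this amine nitrogen. Also open, from the compounds shown here alone, is whether any group here moves the number beyond the scatter.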